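Open chain versus cyclohexyl on the aromatic nitrogen

This account rests on a few compounds, and the source may have more. Where it says the series, first, only, none or still open, it means among the compounds named here.

- Compound 1 `CCCCCn1cc(C(=O)O)c(=O)c2c(O)c(Cc3cccc(Cl)c3F)ccc21` gives 39900 nM
- Compound 2 `O=C(O)c1cn(C2CCCCC2)c2ccc(Cc3cccc(Cl)c3F)c(O)c2c1=O` gives 17400 nM

In an ADME assay on C8166 cells (Homo sapiens) for cytotoxicity, read by MTT assay (on this read-out higher numbers stand for lower toxicity in this test and lower numbers for higher toxicity in this test), compound 2 gives the lower number of the two (17400 nM). Compound 3 `CC(C)[C@@H](CO)n1cc(C(=O)O)c(=O)c2c(O)c(Cc3cccc(Cl)c3F)ccc21` has 1-(hydroxymethyl)-2-methylpropyl in place of cyclohexyl on an aromatic nitrogen. Going by the values given here, the one measured step at this place (a 2.3-fold lower number from compound 1 to compound 2 (0.36 log units; beyond the scatter)) was modest, with cyclohexyl in place of pentyl. A chain with no ring returns, and compound 1 with pentyl gives the higher number (39900 nM), so a modest step upward is expected in this assay. Among the compounds with values here, no measured compound carries a hydroxymethyl, so this direction is uncertain. The expected step is a 1.6-fold higher number from compound 2 to compound 3 (0.19 log units; within the scatter) on this estimate. Estimated for compound 3: 27000 nM (range 11000 nM to 65000 nM).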

Compound 3, half-maximal cytotoxic concentration: 125000 nM
Compound 3: the middle estimate sits 4.6-fold (0.67 log units) below what was measured; measured number outside the range, above it.
By their numbers in this assay, from the lowest: compound 2; then compound 1; then compound 3.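

In this assay, the position on the aromatic nitrogen reaches higher numbers than pentyl and cyclohexyl showed: 1-(hydroxymethyl)-2-methylpropyl in place of cyclohexyl gives a 7.2-fold higher number from compound 2 to compound 3 (0.86 log units; beyond the scatter), and in place of pentyl it gives a 3.1-fold higher number from compound 1 to compound 3 (0.50 log units; beyond the scatter). Among these three compounds, the acyclic group with a hydrogen-bond donor and acceptor therefore stands highest, meaning lowest toxicity in this test. Nothing available explains the rise.

The compounds shown do not separate the hydroxymethyl from the branched chain or the defined stereocentre. As far as these compounds go, a methoxymethyl or an aminomethyl in the same place remains open, as does the opposite stereocentre.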